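Isobutyl to benzyl: reading the amide side chain

This account rests on a few compounds, and the source may have more. Where it says the series, first, only, none or still open, it means among the compounds named here.

In a functional assay on U-937 cells (Homo sapiens) for cytotoxicity, read by MTT assay, with a stated time of 48 h (a higher number here means a weaker inhibitor, a lower number a stronger inhibitor), compound 1 `CNC(=O)CC[C@H](NS(=O)(=O)c1ccc([N+](=O)[O-])cc1)C(=O)O` gives > 500000 nM, which is a limit of the assay and not a number. Compound 2 `CCCCNC(=O)CC[C@H](NS(=O)(=O)c1ccc([N+](=O)[O-])cc1)C(=O)O` reads 94000 nM. Compound 3 `CC(C)CNC(=O)CC[C@H](NS(=O)(=O)c1ccc([N+](=O)[O-])cc1)C(=O)O` reads 93800 nM, so it stands level with compound 2, the two lying within the scatter of each other.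

Compound 4 `O=C(CC[C@H](NS(=O)(=O)c1ccc([N+](=O)[O-])cc1)C(=O)O)NCc1ccccc1` is not yet measured. It carries phenyl in place of isopropyl on a saturated chain carbon bound to an amide-type nitrogen. Cut one bond further out, the same difference reads isobutyl to benzyl.

Two measured steps show what a group at this place can do when it replaces hydrogen: an at least 5.3-fold lower number from compound 1 to compound 2 (0.72 log units; beyond the scatter) and an at least 5.3-fold lower number from compound 1 to compound 3 (0.72 log units; beyond the scatter). The closer guide is the swap of one group for another that is already sizeable, a 1.0-fold lower number from compound 2 to compound 3 (0.00 log units; within the scatter), and that step stays within the scatter. Once such a group is present, then, the numbers in this assay give no sign of a further large move. The expected step is a 1.3-fold lower number from compound 3 to compound 4 (0.13 log units; within the scatter), which means no clear shift beyond the scatter. For compound 4 the estimated value is 70000 nM, with an expected range from 30000 nM to 160000 nM.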

Compound 4, half-maximal inhibitory concentration: 102000 nM
Compound 4: middle estimate off by 1.5-fold (0.16 log units), on the low side; measured number inside the range.
By their numbers in this assay, from the lowest: compounds 3, 2 and 4 (each within the scatter of the next). At a limit, above all of these: compound 1.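

The new result shows that a ring can take this place as well as a chain. With phenyl on the saturated chain carbon bound to the amide-type nitrogen, compound 4 stays level with both alkyl compounds in this assay (a 1.1-fold higher number from compound 3 to compound 4 (0.04 log units; within the scatter) and a 1.1-fold higher number from compound 2 to compound 4 (0.04 log units; within the scatter)), so propyl, isopropyl and phenyl cannot be told apart here, despite the added aromatic ring and the larger count of heavy atoms. Phenyl also reaches the same kind of gain over hydrogen that the two alkyl groups gave (an at least 4.9-fold lower number from compound 1 to compound 4 (0.69 log units; beyond the scatter)), so that gain is not confined to saturated chains among these compounds. Compound 1 remains a limit and not a number, so the true size of that step cannot be read: the limit of > 500000 nM in this assay, at which 1 of the 4 values shown sits.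

The compounds shown leave open whether an amine or a carboxylic acid at this place, or a much longer chain, would move the number beyond the scatter. They also leave open whether a benzyl group carrying a fluorine or a methoxy group would stay level with compound 4 or separate from it.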